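The source may hold more compounds than are shown below. What is called first, only, known or untested is meant among the compounds shown, and "the series" means these compounds.

Measured compounds:
compound 1, `CC(=O)N1CCc2nc(C#Cc3ccccc3)sc2C1`: > 10000 nM in an assay on HEK293 cells for positive allosteric modulation of metabotropic glutamate receptor 5 (Homo sapiens), read by FLIPR, with a stated time of 1 h; a higher number here means that more compound is needed for the effect, a lower number that less compound is needed
compound 2, `O=C(C1CC(F)C1)N1CCc2nc(C#Cc3ccccc3)sc2C1`: 85 nM in this assay

Compound 1 sits at a limit of this assay, (the limit of > 10000 nM in this assay, at which 1 of the 2 values shown sits), and not at a number. Among the measured compounds shown here, compound 2 gives the only number in this set, 85 nM, so it is the sole fixed point. For the measured compounds named here, the single measured step, an at least 110-fold lower number from compound 1 to compound 2 (2.07 log units; beyond the scatter), runs from a methyl on the carbonyl carbon to a 3-fluorocyclobutyl there; it is the only step that speaks to this position.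

Compound 3, `O=C(C1CCCCC1)N1CCc2nc(C#Cc3ccccc3)sc2C1`, is not yet measured. It differs from compound 2 as follows: cyclohexyl in place of 3-fluorocyclobutyl on a carbonyl carbon. The carbonyl thus keeps a carbocyclic substituent while the fluorine goes. Going by the values given here, the measured step shows only that a ring at this position does far better than methyl; it gives no separate reading for the fluorine or for the size of the ring. Compound 2 and compound 3 are therefore expected to lie near each other, with the step of a 2.4-fold higher number from compound 2 to compound 3 (0.37 log units; beyond the scatter) expected to stay within or only just beyond the scatter. Compound 3 is estimated at 200 nM, in the range 50 nM to 800 nM.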

Compound 3, half-maximal effective concentration: 167 nM
For compound 3 the middle estimate is 1.2-fold (0.08 log units) above the measured one, within the range that was stated.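

In this assay, cyclohexyl in place of 3-fluorocyclobutyl on the carbonyl carbon gives a 2.0-fold higher number from compound 2 to compound 3 (0.29 log units; within the scatter), so compound 2 and compound 3 cannot be told apart, and neither the fluorine nor the four-membered ring is required for a value in this range. Against methyl, cyclohexyl gives an at least 59-fold lower number from compound 1 to compound 3 (1.77 log units; beyond the scatter), so the large step previously seen with 3-fluorocyclobutyl alone now holds for two different carbocyclic rings on this carbonyl. Compound 1 is a limit and not a number, so both steps from it give only a minimum size: the limit of > 10000 nM in this assay, at which 1 of the 3 values shown sits.

The fluorine and the ring size change together between compound 2 and compound 3, so the contribution of each remains unresolved; plain cyclobutyl or a fluorocyclohexyl would separate them. Also open, as far as these compounds go, are whether a ring is needed at all, which an open-chain group such as isobutyl would test, and how this carbonyl substituent tolerates an aromatic phenyl or a ring carrying an amine or a carboxylic acid.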